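Lengthening the Amide Substituent on Compound 2

The source may report more compounds than this note shows. Statements on the series, on what has been measured and on what is new or still open speak of the compounds shown alone.

Among the measured compounds shown here, compound 2 `CNC(=O)[C@H]1O[C@@H](n2cnc3c(NOC)nc(I)nc32)[C@H](O)[C@@H]1O` holds the lowest number so far in an assay on CHO cells for displacement of a labelled ligand from adenosine receptor A3 (Homo sapiens) (a lower number here means a stronger inhibitor, a higher number a weaker inhibitor), with compound 2 at 1.7 nM. Its nearest neighbour is compound 1 `CONc1nc(C#CCCCC#N)nc2c1ncn2[C@@H]1O[C@H](CO)[C@@H](O)[C@H]1O`, which in this assay gives 4.1 nM, a gap beyond the usual scatter. Compound 3 `CCNC(=O)[C@H]1O[C@@H](n2cnc3c(NOC)nc(I)nc32)[C@H](O)[C@@H]1O` differs from compound 2 only by methyl in place of hydrogen on a saturated chain carbon bound to an amide-type nitrogen, so the methylcarbamoyl group becomes ethylcarbamoyl. For the measured compounds named here, no measured pair shows this change, so its effect is not documented here. For compound 3 a modest weakening is expected, the estimated step being a 2.9-fold higher number from compound 2 to compound 3 (0.47 log units; beyond the scatter). Compound 3 is therefore expected to give 5 nM in this assay, within a range from 1.5 nM to 16 nM.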

Compound 3, inhibition constant: 2.8 nM
Compound 3: middle estimate off by 1.8-fold (0.25 log units), on the high side; the measured number falls inside the stated range.
By their numbers in this assay, from the lowest: compounds 2, 3 and 1 (each within the scatter of the next, the first and the last beyond it).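

Among the compounds shown here, this pair gives the first direct reading of this change: in this assay, methyl in place of hydrogen on a saturated chain carbon bound to an amide-type nitrogen gives a 1.6-fold higher number from compound 2 to compound 3 (0.22 log units; within the scatter). The ethylcarbamoyl group therefore performs on a par with the methylcarbamoyl group, and the two compounds cannot be told apart here. No measurement shown explains this result.

A single added methyl leaves open how far the chain can grow. Going by these compounds, whether a longer chain, as in propylcarbamoyl or butylcarbamoyl, or a ring, as in cyclopropylcarbamoyl, would behave the same remains unknown.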